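This account rests on a few compounds, and the source may have more. Where it says the series, first, only, none or still open, it means among the compounds named here.

The measured compounds:

Compound 1, `COc1nc(N)nc2c1c(-c1ccsc1)cn2[C@@H]1O[C@H](CO)[C@@H](O)[C@H]1O`: in an ADME assay on BJ cells (Homo sapiens), read by MTT assay, with a stated time of 72 h (a higher number here means a weaker inhibitor, a lower number a stronger inhibitor), compound 1 gives > 100000 nM, which is a limit of the assay and not a number.
Compound 2, `C#Cc1cn([C@@H]2O[C@H](CO)[C@@H](O)[C@H]2O)c2nc(N)nc(OC)c12`: in this assay compound 2 gives > 100000 nM, again a limit of the assay.
Among the measured compounds shown here, compound 3, `C#Cc1cn([C@@H]2O[C@H](CO)[C@@H](O)[C@H]2O)c2ncnc(SC)c12`: in this assay compound 3 gives 68600 nM, the only number among the three.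

Compound 2 and compound 1 differ in one place: thiophen-3-yl in place of ethynyl on an aromatic carbon. The step that the two limits leave unreadable from compound 2 to compound 1 cannot be read, because both values sit at the limit of > 100000 nM in this assay, at which 2 of the 3 values shown sit.

Compound 4, `CSc1ncnc2c1c(-c1ccsc1)cn2[C@@H]1O[C@H](CO)[C@@H](O)[C@H]1O`, has not yet been measured in this assay. It differs from compound 3 in the same way: thiophen-3-yl in place of ethynyl on an aromatic carbon. The cores of compound 3 and compound 2 differ, and that difference is not broken down here. The earlier instance of this change gives no readable size, so the expectation for compound 4 rests mainly on the weak value of compound 3, 68600 nM, and allows a step of a 1.3-fold higher number from compound 3 to compound 4 (0.12 log units; within the scatter) in either direction. Compound 4 is expected to give roughly 90000 nM in this assay, estimated between 30000 nM and 300000 nM, with a fair chance that only a limit is reported.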

Compound 4, half-maximal inhibitory concentration: 95800 nM
The estimate for compound 4 lay 1.1-fold (0.03 log units) below the measured number; low and high end bracket the measured number.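

In this assay, putting thiophen-3-yl in place of ethynyl on the core of compound 3 gives a 1.4-fold higher number from compound 3 to compound 4 (0.15 log units; within the scatter), so on this core the change leaves the number within the usual scatter. On these data alone, the same change on the core of compound 2 cannot be read, as compound 2 and compound 1 both stand at a limit and not at a number: the limit of > 100000 nM in this assay, at which 2 of the 4 values shown sit. The series therefore offers one readable instance of this change, which shows no shift on one core but does not show whether the same holds on the other, so carrying it from core to core remains untested here.

The compounds shown carry only ethynyl or thiophen-3-yl on this aromatic carbon, which leaves open what a phenyl ring, an amine or a carboxylic acid there would do to the number. They also leave open how the two cores compare on their own, since compound 3 and compound 2 differ in more than one place.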